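Series notes: bromo to methyl on the aromatic ring

The compounds below may be only part of what the source reports. "The series", "measured", "known", "first", "only" and "open" are said of these compounds alone.

Measured so far:
compound 1 `COc1ccc(/C=C/C(=O)c2c(C)[n+]([O-])c3ccccc3[n+]2[O-])cc1OC` gives 38000 nM in a functional assay on HSC-4 cells (Homo sapiens) for cytotoxicity, with a stated time of 48 h; a lower number here means that less compound is tolerated, a higher number that more compound is tolerated
compound 2 `Cc1c(C(=O)/C=C/c2ccc(Br)cc2)[n+]([O-])c2ccccc2[n+]1[O-]` gives 36000 nM in this assay

Compound 2 holds the lowest of the two numbers, but its nearest neighbour compound 1 sits within the scatter, so no order between them can be drawn. Compound 3 `Cc1ccc(/C=C/C(=O)c2c(C)[n+]([O-])c3ccccc3[n+]2[O-])cc1` differs from compound 2 by methyl in place of bromo on an aromatic carbon. Going by the values given here, no measured pair shows this change, so the step in this assay is expected to be small and in neither direction beyond the scatter. Compound 3 is estimated at 40000 nM, with a range of 15000 nM to 100000 nM. The expected step is a 1.1-fold higher number from compound 2 to compound 3 (0.05 log units; within the scatter).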

Compound 3, half-maximal cytotoxic concentration: 11000 nM
Estimate against measurement, compound 3: 3.6-fold (0.56 log units) above; measured number below the stated range.
By their numbers in this assay, from the lowest: compound 3; then compounds 2 and 1 (each within the scatter of the next).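

In this assay there is a 3.3-fold lower number from compound 2 to compound 3 (0.51 log units; beyond the scatter) on going from 4-bromophenyl to 4-methylphenyl, the first difference in the series that lies beyond the scatter. The group on this aromatic carbon, para to a large group, therefore moves the number, even with one heavy atom exchanged for one heavy atom. No available data explain this step.

Still open, going by these compounds, is how a chloro, a trifluoromethyl or an amine on this carbon would read. Also open, on these data alone, is whether the same exchange gives a similar step on another core.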